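From 3-methylbenzyl to 2-methoxybenzyl on a shared core

The source may hold more compounds than are shown below. What is called first, only, known or untested is meant among the compounds shown, and "the series" means these compounds.

In a functional assay on HL-60 cells (Homo sapiens) for antiproliferative activity, with a stated time of 72 h (on this read-out higher numbers stand for weaker inhibition and lower numbers for stronger inhibition), three compounds with a shared core differ only in one group on an aromatic carbon. Compound 1 `OC[C@H]1O[C@@H](n2cnc3c(NCc4cccc(F)c4)ncnc32)[C@H](O)[C@@H]1O` gives 920 nM, compound 2 `OC[C@H]1O[C@@H](n2cnc3c(NCc4cccc(Br)c4)ncnc32)[C@H](O)[C@@H]1O` gives 8000 nM, and compound 3 `Cc1cccc(CNc2ncnc3c2ncn3[C@@H]2O[C@H](CO)[C@@H](O)[C@H]2O)c1` gives 6400 nM. Replacing fluoro with bromo gives an 8.7-fold higher number from compound 1 to compound 2 (0.94 log units; beyond the scatter), and replacing fluoro with methyl gives a 7.0-fold higher number from compound 1 to compound 3 (0.84 log units; beyond the scatter). Compound 3 thus stands with compound 2 at the high end of these numbers, as replacing bromo with methyl gives a 1.3-fold lower number from compound 2 to compound 3 (0.10 log units; within the scatter).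

Compound 4 `COc1ccccc1CNc1ncnc2c1ncn2[C@@H]1O[C@H](CO)[C@@H](O)[C@H]1O` departs from compound 3 by a larger change: 2-methoxyphenyl in place of 3-methylphenyl on a saturated chain carbon bound to a nitrogen on an aromatic ring. It places 2-methoxyphenyl in place of 3-methylphenyl on a saturated chain carbon bound to a nitrogen on an aromatic ring. The steps from compound 1 and compound 2 to compound 3 are the nearest guides, but neither involves a methoxy group, so they show only how large a change in this group can be. A step within the scatter is expected, leaning slightly lower, and the estimate is a 1.8-fold lower number from compound 3 to compound 4 (0.26 log units; within the scatter). Compound 4 is expected at 3500 nM. The estimated range for compound 4 runs from 900 nM to 13000 nM.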

Compound 4, half-maximal inhibitory concentration: 2300 nM
Estimate against measurement, compound 4: 1.5-fold (0.18 log units) above; the range from low to high includes it.
By their numbers in this assay, from the lowest: compound 1; then compound 4; then compounds 3 and 2 (each within the scatter of the next).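

In this assay, among the compounds shown here, 2-methoxyphenyl is the first group in this set to bring the number down from the level shared by the bromo and methyl compounds: in place of 3-methylphenyl it gives a 2.8-fold lower number from compound 3 to compound 4 (0.44 log units; beyond the scatter) and in place of 3-bromophenyl it gives a 3.5-fold lower number from compound 2 to compound 4 (0.54 log units; beyond the scatter) without matching 3-fluorophenyl. The remaining step, a 2.5-fold higher number from compound 1 to compound 4 (0.40 log units; beyond the scatter), places compound 4 between compound 1 and the other two. Because the substituent and its ring position both change, these steps cannot be assigned to the methoxy group or to its position alone, and no supporting data explain them.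

On these data alone, it remains open how a methoxy group would read as 3-methoxyphenyl. As far as these compounds go, the effect of an amine or a carboxylic acid on the phenyl ring also remains open.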